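The source may hold more compounds than are shown below. What is called first, only, known or untested is meant among the compounds shown, and "the series" means these compounds.

Measured compounds:
- compound 1 `Clc1ccc(-c2nnc(SCCCN3CCN(c4cccc(Cl)c4)CC3)[nH]2)cc1`: in a functional assay on COLO 205 cells (Homo sapiens) for cytotoxicity, read by MTT assay, with a stated time of 24 h (a lower number here means a stronger inhibitor, a higher number a weaker inhibitor), compound 1 gives > 300000 nM, a limit of the assay.
- compound 2 `CC(C)(C)c1ccc(-c2nn(CCCN3CCN(c4ccccc4)CC3)c(=S)[nH]2)cc1`: in this assay compound 2 gives > 300000 nM, again a limit.
- compound 3 `CC(C)(C)c1ccc(-c2nn(CCCN3CCN(c4cccc(Cl)c4)CC3)c(=S)[nH]2)cc1`: in this assay compound 3 gives > 300000 nM, also a limit.

Compound 3 therefore stands only at a limit, and the two other values are limits as well. Going by the values given here, the one step between close pairs, a step that the two limits leave unreadable from compound 2 to compound 3, cannot be read for the same reason. Among the compounds with values here, the only evidence on the measured steps is the limit of > 300000 nM in this assay, at which 3 of the 3 values shown sit, which says no more than that no compound reaches the measurable range.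

Compound 4 `Cc1ccc(-c2nn(CCCN3CCN(c4cccc(Cl)c4)CC3)c(=S)[nH]2)cc1` is not yet measured. It differs from compound 3 in one place: methyl in place of tert-butyl on an aromatic carbon. Within the data shown here, no measured step bears on this change directly, and the step that exists, from a hydrogen to a chloro on an aromatic carbon, is itself unreadable. With all three values sitting at the limit, nothing points to a step beyond the scatter in either direction; the expectation is that compound 4 also remains at the limit, the expected step being a number no higher from compound 3 to compound 4 (the limit leaves the size open). For compound 4 in this assay the estimate is 300000 nM, in the range 100000 nM to 1000000 nM, most likely reported only as a limit.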

Compound 4, half-maximal inhibitory concentration: > 300000 nM
Compound 4 was reported as a limit; the forecaster's own chance of this, stated with the estimate: 85%; the middle value sits exactly at the limit.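

Compound 3 and compound 4 both stand only as limits in this assay, so methyl in place of tert-butyl gives no readable step, and no new step can be read from this pair: the limit of > 300000 nM in this assay, at which 4 of the 4 values shown sit. The compounds shown leave open which change to the shared core, if any, would bring a value into the measurable range.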